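Cinnamylidene to aryl hydrazides: tolerance in HEL cells

The compounds below may be only part of what the source reports. "The series", "measured", "known", "first", "only" and "open" are said of these compounds alone.

Compound 1 `O=C(COc1cccc2ccccc12)N/N=C/C=C/c1ccccc1` and compound 2 `O=C(COc1cccc2ccccc12)N/N=C/c1ccc(Br)cc1` share a core that carries a naphthyloxyacetyl hydrazide. In an ADME assay on HEL cells (Homo sapiens) for cytotoxicity (a lower number here means that less compound is tolerated, a higher number that more compound is tolerated), compound 1 gives 100 ug/mL, and compound 2 gives 100 ug/mL. Going by the values given here, the one measured step, no change at the digits printed from compound 1 to compound 2 (within the scatter), shows that swapping the group on the imine carbon left tolerance unchanged, so compound 2 stands level with compound 1 in this assay. Compound 3 `O=C(COc1cccc2ccccc12)N/N=C/c1ccccc1O` is the next member: 2-hydroxyphenyl in place of 4-bromophenyl on a carbon with a double bond to nitrogen. Among the compounds with values here, no measured step covers a hydroxyphenyl at this position, and the only step that bears on it, from compound 1 to compound 2, was flat. On that basis the expected step of no change at the digits printed from compound 2 to compound 3 (within the scatter) is none beyond the scatter. Compound 3 is therefore expected to give about 100 ug/mL in this assay, with a range from 50 ug/mL to 150 ug/mL.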

Compound 3, half-maximal cytotoxic concentration: 3.57 ug/mL
Compound 3: middle estimate off by 28-fold (1.45 log units), on the high side; measured number outside the range, below it.
By their numbers in this assay, from the lowest: compound 3; then compounds 1 and 2 (each within the scatter of the next).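

The place on a carbon with a double bond to nitrogen is not indifferent in this assay: the change to 2-hydroxyphenyl gives a 28-fold lower number from compound 2 to compound 3 (1.45 log units; beyond the scatter) and also a 28-fold lower number from compound 1 to compound 3 (1.45 log units; beyond the scatter) in this series. The earlier no change at the digits printed from compound 1 to compound 2 (within the scatter) showed only that two groups could be exchanged without a shift; unlike 4-bromophenyl, the entering 2-hydroxyphenyl carries a hydrogen-bond donor and a hydrogen-bond acceptor, although that difference is not shown to account for the drop. No measurement at hand gives a reason for the lower number.

As far as these compounds go, whether the hydroxy group is required remains open, as a methoxyphenyl or an aminophenyl at this place would be needed to test it. A single hydroxyphenyl compound also leaves open how general the drop is across the series.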